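From a Chlorohexyl Urea to a Chlorophenyl Amide

A few compounds are considered here, and "the series" means these few. Any claim that something is new, unique, unknown or untested is made for them only; others in the source may bear on it.

Compound 1, `O=C(Nc1c(C(O)(C(F)(F)F)C(F)(F)F)ccc2ccccc12)C1CC1`: in an assay on LtK cells with ATP-sensitive inward rectifier potassium channel 11 (Homo sapiens) as the target (a lower number here means that less compound is needed, a higher number that more compound is needed for the effect), compound 1 gives 751 nM.
Compound 2, `COCC(=O)Nc1c(C(O)(C(F)(F)F)C(F)(F)F)ccc2ccccc12`: in this assay compound 2 gives 213 nM.
Compound 3, `O=C(NCCCCCCCl)Nc1c(C(O)(C(F)(F)F)C(F)(F)F)ccc2ccccc12`: in this assay compound 3 gives 4840 nM.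

All three share one core and differ only in the group on the carbonyl carbon of the amide. Compound 3 has the highest number of the three: the nearest is compound 1 (a 6.4-fold higher number from compound 1 to compound 3 (0.81 log units; beyond the scatter)), and the furthest is compound 2 (a 23-fold higher number from compound 2 to compound 3 (1.36 log units; beyond the scatter)).

Compound 4, `O=C(Nc1c(C(O)(C(F)(F)F)C(F)(F)F)ccc2ccccc12)c1cccc(Cl)c1`, has not been measured. Its change from compound 3 is 3-chlorophenyl in place of (6-chlorohexyl)amino on a carbonyl carbon. Both measured steps that end at compound 3 arrive from a compound carrying a smaller group on that carbonyl carbon, and both raise the number: a 6.4-fold higher number from compound 1 to compound 3 (0.81 log units; beyond the scatter) and a 23-fold higher number from compound 2 to compound 3 (1.36 log units; beyond the scatter). Compound 4 moves the other way, away from the (6-chlorohexyl)amino group, so a lower number is expected in this assay. A 3-chlorophenyl group has not been seen in this series, so the size of the step is uncertain. Compound 4 is estimated at 600 nM, with a range from 120 nM to 3000 nM, and the expected step is an 8.1-fold lower number from compound 3 to compound 4 (0.91 log units; beyond the scatter).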

Compound 4, half-maximal effective concentration: 98 nM
For compound 4 the middle estimate is 6.1-fold (0.79 log units) above the measured one; measured number below the stated range.
By their numbers in this assay, from the lowest: compound 4; then compound 2; then compound 1; then compound 3.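

The carbonyl carbon, so far seen with cyclopropyl, methoxymethyl and (6-chlorohexyl)amino, now carries an aromatic ring, and 3-chlorophenyl gives the lowest number of the four in this assay, with a 2.2-fold lower number from compound 2 to compound 4 (0.34 log units; beyond the scatter) and a 7.7-fold lower number from compound 1 to compound 4 (0.88 log units; beyond the scatter). A large group here therefore does not by itself bring a high number, as a 49-fold lower number from compound 3 to compound 4 (1.69 log units; beyond the scatter) replaces one large group with another of similar heavy-atom count, yet the result moves sharply the other way. Nothing measured here explains this difference.

That step swaps the chain and its nitrogen for the ring together, so the effect of each remains unseparated. A (3-chlorophenyl)amino group would part the two, and an unsubstituted phenyl group would show what the chlorine contributes.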